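Carbonyl substituent change from compound 1 to compound 4

The source may hold more compounds than are shown below. What is called first, only, known or untested is meant among the compounds shown, and "the series" means these compounds.

Measured so far:
compound 1, `CN(C(=O)c1ccc(Cl)cc1)c1ccc2[nH]c(-c3n[nH]c4ccccc34)cc2n1`: 2420 nM
compound 2, `COc1ccc(OC)c(S(=O)(=O)N(C)c2ccc3[nH]c(-c4n[nH]c5ccccc45)cc3n2)c1`: 4280 nM
compound 3, `CN(c1ccc2[nH]c(-c3n[nH]c4ccccc34)cc2n1)S(=O)(=O)c1ccc(OC(F)(F)F)cc1`: 7160 nM

All three share one core and differ only in the group carried on the methylated nitrogen. In a functional assay on SMMC-7721 cells (Homo sapiens) for antiproliferative activity, read by MTT assay, with a stated time of 72 h (on this read-out higher numbers stand for weaker inhibition and lower numbers for stronger inhibition), compound 1 stands at the lowest of the three numbers; compound 2 sits within the scatter of it, while compound 3 lies beyond the scatter of compound 1. Going by the values given here, the single measured step, a 1.7-fold higher number from compound 2 to compound 3 (0.22 log units; within the scatter), exchanges one aryl group for another on a sulfonyl sulfur; it says nothing about what happens at a carbonyl carbon, and compound 1 is the only carbonyl-bearing member of the set.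

Compound 4, `CN(C(=O)Nc1ccccc1)c1ccc2[nH]c(-c3n[nH]c4ccccc34)cc2n1`, is the next member. Relative to compound 1 the change is anilino in place of 4-chlorophenyl on a carbonyl carbon. Among the compounds with values here, no measured pair covers this kind of exchange, so there is no step to lean on. With nothing in the set pointing either way, the expectation is that compound 4 stays close to compound 1 in this assay; the estimated step of a 1.0-fold lower number from compound 1 to compound 4 (0.00 log units; within the scatter) is taken as lying within the scatter. The estimated value for compound 4 is therefore 2400 nM, with a range from 800 nM to 7500 nM.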

Compound 4, half-maximal inhibitory concentration: 280 nM
Beside the measured number, compound 4's estimate is 8.6-fold (0.93 log units) above it, and the stated range ends above it.
By their numbers in this assay, from the lowest: compound 4; then compounds 1, 2 and 3 (each within the scatter of the next, the first and the last beyond it).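

In this assay, going by these compounds alone, the step of an 8.6-fold lower number from compound 1 to compound 4 (0.94 log units; beyond the scatter) is the first exchange to go beyond the scatter, and it shows that the group on a carbonyl carbon can move this read-out, which the earlier step on a sulfonyl sulfur did not. The two groups match in the counts computed for them, with 7 heavy atoms and one six-membered aromatic ring of carbon only each, so the difference lies in chlorine leaving, nitrogen entering and the donor that comes with the anilino group, turning (4-chlorophenyl)carbonyl into phenylcarbamoyl. No measurement at hand accounts for the size of this step.

This single exchange does not separate the loss of chlorine from the entry of nitrogen; plain phenyl and 4-chloroanilino, each on a carbonyl carbon, would pull the two apart. Also open, from the compounds shown here alone, is whether the lower number depends on the amide hydrogen and the aromatic ring, a question that piperidine or cyclohexylamino on the same carbonyl carbon would address.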